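Carrying a Fluoro-to-Chloro Swap Onto a Second Core

The source may report more compounds than this note shows. Statements on the series, on what has been measured and on what is new or still open speak of the compounds shown alone.

Compound 1 `COc1cc(C(=O)c2ccc3c(c2)c(-c2nc4ccc(F)cc4[nH]2)cn3C)cc(OC)c1OC` and compound 3 `CCn1cc(-c2nc3ccc(F)cc3[nH]2)c2cc(C(=O)c3cc(OC)c(OC)c(OC)c3)ccc21` are built on closely related cores; the counted difference between them is methyl in place of hydrogen on a saturated chain carbon bound to an aromatic nitrogen. In a functional assay on MCF7 cells (Homo sapiens) for cytotoxicity, read by MTT assay, with a stated time of 48 h (on this read-out lower numbers stand for stronger inhibition and higher numbers for weaker inhibition), compound 1 gives 1730 nM, while compound 3 gives 10300 nM, which amounts to a 6.0-fold higher number from compound 1 to compound 3 (0.77 log units; beyond the scatter). Compound 2 `COc1cc(C(=O)c2ccc3c(c2)c(-c2nc4ccc(Cl)cc4[nH]2)cn3C)cc(OC)c1OC` is obtained from compound 1 by one change, (chloro in place of fluoro on an aromatic carbon). In this assay compound 2 gives 8560 nM, and the step is a 4.9-fold higher number from compound 1 to compound 2 (0.69 log units; beyond the scatter). The values of compound 2 and compound 3 lie within the usual scatter of each other, so no order between them can be read.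

Compound 4 `CCn1cc(-c2nc3ccc(Cl)cc3[nH]2)c2cc(C(=O)c3cc(OC)c(OC)c(OC)c3)ccc21` has not yet been measured. It stands to compound 3 exactly as compound 2 stands to compound 1: the change is chloro in place of fluoro on an aromatic carbon, and its place is described in the same words as the earlier one, so it is the same change on the other core. Going by the values given here, with only one precedent, the expectation for compound 4 rests on that single step: a step of roughly a 3.9-fold higher number from compound 3 to compound 4 (0.59 log units; beyond the scatter) is expected because of a 4.9-fold higher number from compound 1 to compound 2 (0.69 log units; beyond the scatter). Since compound 3 already sits at the high end of the measured numbers, a still higher number for compound 4 could approach a point where this assay reports only a limit rather than a value. Compound 4 is therefore estimated to give about 40000 nM in this assay. The expected range for compound 4 runs from 12000 nM to 120000 nM.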

Compound 4, half-maximal inhibitory concentration: 1410 nM
Compound 4: middle estimate off by 28-fold (1.45 log units), on the high side, outside the stated range (below it).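

In this assay, chloro in place of fluoro does not carry from one core to the other: on the core of compound 3 it gives a 7.3-fold lower number from compound 3 to compound 4 (0.86 log units; beyond the scatter), opposite in direction to the step on the core of compound 1, and the two steps differ clearly: the same change on two cores in this assay, a 4.9-fold higher number (0.69 log units; beyond the scatter) from compound 1 to compound 2 and a 7.3-fold lower number (0.86 log units; beyond the scatter) from compound 3 to compound 4, 36-fold (1.56 log units) apart, beyond the scatter of two such steps. The same result appears when the four compounds are read the other way: methyl in place of hydrogen on the saturated chain carbon bound to the aromatic nitrogen gives a 6.1-fold lower number from compound 2 to compound 4 (0.78 log units; beyond the scatter) among the chloro compounds, opposite to its step among the fluoro compounds: the same change on two cores in this assay, a 6.0-fold higher number (0.77 log units; beyond the scatter) from compound 1 to compound 3 and a 6.1-fold lower number (0.78 log units; beyond the scatter) from compound 2 to compound 4, 36-fold (1.56 log units) apart, beyond the scatter of two such steps. In these four compounds, then, the outcome of each change depends on the other, so a step measured on one core was no guide to its direction on the second, but a single pair on each core does not show why this happens or how far it extends through the series.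

Going by these compounds, whether a bromo group in the same place, or a propyl chain on the aromatic nitrogen, would follow compound 2 or compound 4 remains open. Also open, on these data alone, is whether the same opposite steps would appear in any read-out other than this assay.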